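Urea tail change on the shared core: compound 2 to compound 3

This account rests on a few compounds, and the source may have more. Where it says the series, first, only, none or still open, it means among the compounds named here.

Measured compounds:
compound 1 `Cc1cc(C(=O)N2CCCCc3ccccc32)cc(C)c1CNC(=O)Nc1c(F)cccc1F` — 82 nM
compound 2 `Cc1cc(C(=O)N2CCCCc3ccccc32)ccc1CNC(=O)NCC(=O)OC(C)(C)C` — 120 nM

In a functional assay on HEK293 cells for agonist activity at Vasopressin V2 receptor (Homo sapiens), read by a luciferase reporter and cAMP accumulation (on this read-out higher numbers stand for an effect only at larger amounts of compound and lower numbers for an effect already at smaller amounts), compound 1 gives 82 nM and compound 2 gives 120 nM. Among the compounds with values here, the two numbers lie within the usual scatter of each other, so compound 2 does not stand apart from compound 1 on these data; no step between the two is counted, since they differ in more than one place.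

Compound 3 `Cc1cc(C(=O)N2CCCCc3ccccc32)ccc1CNC(=O)N1CCC[C@H]1C(=O)OC(C)(C)C` is the next member. From compound 2 to compound 3 the change is 2-(tert-butoxycarbonyl)pyrrolidin-1-yl in place of ((tert-butoxycarbonyl)methyl)amino on a carbonyl carbon. The chain-type urea substituent is thus replaced by a ring-closed one that carries the same ester and no hydrogen-bond donor. Within the data shown here, no measured pair in this set covers such a change, so the size of the step can only be guessed from the general spread of the two numbers at hand.

The step from compound 2 to compound 3 is expected to be a 1.7-fold higher number from compound 2 to compound 3 (0.22 log units; within the scatter), most likely toward a somewhat higher number, though a step within the scatter cannot be excluded. Compound 3 is estimated at 200 nM, with a range from 60 nM to 700 nM.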

Compound 3, half-maximal effective concentration: 390 nM
Compound 3: middle estimate off by 2.0-fold (0.29 log units), on the low side; measured number inside the range.
By their numbers in this assay, from the lowest: compounds 1 and 2 (each within the scatter of the next); then compound 3.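

In this assay, within the data shown here, this urea position on the shared core gives the first readable step: 2-(tert-butoxycarbonyl)pyrrolidin-1-yl in place of ((tert-butoxycarbonyl)methyl)amino on a carbonyl carbon gives a 3.3-fold higher number from compound 2 to compound 3 (0.51 log units; beyond the scatter), so this position is sensitive to the change, at least in this one pair. The tert-butyl ester is present on both sides, but the entering group also adds a five-membered non-aromatic ring and a defined stereocentre, and it has no hydrogen-bond donor, so this single step cannot separate the contributions of these differences. No supporting data bear on why the number moves.

From the compounds shown here alone, it remains open whether the ring, the missing hydrogen-bond donor or the stereocentre accounts for the step, which would take an open-chain tertiary urea carrying a methyl group on the nitrogen, and the opposite stereocentre on the pyrrolidine, to separate. Also open, going by these compounds, is how a carboxylic acid in place of the tert-butyl ester, or a six-membered piperidine ring in place of the pyrrolidine, would stand at this position on the same core.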